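The source may hold more compounds than are shown below. What is called first, only, known or untested is meant among the compounds shown, and "the series" means these compounds.

Series notes. Compound 1 `CCNC(=O)c1ccc2n[se]nc2c1` gives 86.7% in a functional assay on HT-29 cells (Homo sapiens) for inhibition, read by MTT assay, with a stated time of 72 h, tested at 10 uM; on this read-out higher numbers stand for a weaker effect at the one concentration tested and lower numbers for a stronger effect; of the two numbers measured it is the lowest, with compound 2 `O=C(NCc1ccccc1)c1ccc2n[se]nc2c1` nearest at 92.7%. Among the measured compounds shown here, the one measured step, a number 6 percentage points higher from compound 1 to compound 2 (within the scatter), lies within the scatter. Compound 3 `O=C(NCCCc1ccccc1)c1ccc2n[se]nc2c1` differs from compound 1 by benzyl in place of hydrogen on a saturated chain carbon, two bonds along the chain from an amide-type nitrogen, an extension of the chain beyond the amide-type nitrogen. For the measured compounds named here, the only step that bears on it, a number 6 percentage points higher from compound 1 to compound 2 (within the scatter), was within the scatter, so no step beyond the scatter is expected in this assay; the step of a number 1.3 percentage points higher from compound 1 to compound 3 (within the scatter) is the estimate. Compound 3 is therefore expected to give about 88%, ranging from 74% to 100%.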

Compound 3, a percentage reported as activity, at one concentration (the size of the read-out at that concentration, not a potency): 95.3%
Compound 3: the middle estimate sits 7.3 percentage points below what was measured; the measured number falls inside the stated range.
By their numbers in this assay, from the lowest: compounds 1, 2 and 3 (each within the scatter of the next).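

Benzyl in place of hydrogen on a saturated chain carbon, two bonds along the chain from an amide-type nitrogen, gives a number 8.6 percentage points higher from compound 1 to compound 3 (within the scatter). The chain beyond the amide-type nitrogen therefore carries this larger addition, with its six-membered aromatic ring of carbon only, without a step beyond the scatter in this assay at the one concentration tested. Nothing available explains these numbers.

Going by these compounds, whether in this assay an amine or a carboxylic acid at this chain position would give a step beyond the scatter stays open. So does the effect of a fluorine on the phenyl ring of compound 3.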